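A few compounds are considered here, and "the series" means these few. Any claim that something is new, unique, unknown or untested is made for them only; others in the source may bear on it.

Of the compounds shown here, three built on one shared core have been measured in a functional assay on SK-N-SH cells (Homo sapiens) for inhibition, read by sulforhodamine B assay, with a stated time of 48 h; a higher number here means a weaker inhibitor, a lower number a stronger inhibitor. Compound 1 `CO[C@@H]1CC=C2NN(c3cc(F)cc(Cl)c3)C(=O)C[C@]2(c2ccccc2)O1` gives 17400 nM. Compound 2 `CO[C@@H]1CC=C2NN(c3ccc(C)cc3)C(=O)C[C@]2(C)O1` gives 25300 nM, and compound 3 `CO[C@@H]1CC=C2NN(c3ccc(C)cc3)C(=O)C[C@]2(c2ccncc2)O1` gives 8100 nM. Among these three numbers compound 1 holds the second highest; its value and that of compound 2 fall within the scatter of each other, whereas compound 3 lies beyond the scatter on the lower side. For the measured compounds named here, the only single-point step available, a 3.1-fold lower number from compound 2 to compound 3 (0.49 log units; beyond the scatter), concerns the saturated ring carbon. Compound 4 `CO[C@@H]1CC=C2NN(c3cncnc3)C(=O)C[C@]2(c2ccccc2)O1` differs from compound 1 elsewhere: pyrimidin-5-yl in place of 3-chloro-5-fluorophenyl on an amide-type nitrogen in a ring. Going by the values given here, no measured step touches the group on this amide-type nitrogen, so the data give no basis for a shift in this assay beyond the scatter. The step of a 1.0-fold lower number from compound 1 to compound 4 (0.01 log units; within the scatter) is therefore expected to be small. Compound 4 is estimated at 17000 nM, within 6000 nM to 50000 nM.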

Compound 4, half-maximal inhibitory concentration: 8200 nM
The estimate for compound 4 lay 2.1-fold (0.32 log units) above the measured number; the measured number falls inside the stated range.
By their numbers in this assay, from the lowest: compounds 3 and 4 (each within the scatter of the next); then compounds 1 and 2 (each within the scatter of the next).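

In this assay, for the compounds shown here, the change on the amide-type nitrogen gives a 2.1-fold lower number from compound 1 to compound 4 (0.33 log units; beyond the scatter) and is the first step to show that the group held there can move the number beyond the scatter, if only modestly. A six-membered aromatic ring with 2 hetero atoms and no halogen is accepted here without loss. Nothing measured on these compounds accounts for the shift.

The compounds shown do not separate the loss of chlorine and fluorine from the entry of the ring nitrogens. From the compounds shown here alone, how an unsubstituted phenyl or a pyridin-3-yl on this nitrogen would read remains open.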